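A few compounds are considered here, and "the series" means these few. Any claim that something is new, unique, unknown or untested is made for them only; others in the source may bear on it.

Measured so far:
Compound 1, `O=C(/C=C\Nc1cnc2ccccc2c1)c1nc(-c2ccc(C(F)(F)F)cc2)n2ccccc12`, which in a functional assay on HCT-116 cells (Homo sapiens) for cytotoxicity, read by MTT assay, with a stated time of 48 h (a higher number here means a weaker inhibitor, a lower number a stronger inhibitor), gives only a limit, > 30000 nM.
Compound 2, `COc1ccc(N/C=C\C(=O)c2nc(-c3ccc(C(F)(F)F)cc3)n3ccccc23)cc1`, which in this assay gives 7720 nM.

Going by the values given here, compound 2 thus holds the only number in this assay; the other value is a limit (the limit of > 30000 nM in this assay, at which 1 of the 2 values shown sits). Among the compounds with values here, the one measured step, an at least 3.8-fold lower number from compound 1 to compound 2 (0.58 log units; beyond the scatter), concerns the group on the amine nitrogen.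

Compound 3, `COc1ccc(N/C=C\C(=O)c2nc(-c3ccc(C(F)(F)F)cc3)n3ccccc23)cc1OC`, differs from compound 2 by methoxy in place of hydrogen on an aromatic carbon. No measured step touches the aromatic ring that carries the methoxy group, so the only step shown, an at least 3.8-fold lower number from compound 1 to compound 2 (0.58 log units; beyond the scatter), bears on it at best indirectly. The expectation for compound 3 is therefore a step of a 1.1-fold lower number from compound 2 to compound 3 (0.04 log units; within the scatter), no larger than the scatter, in either direction. Compound 3 is estimated at 7000 nM, with a range from 2000 nM to 25000 nM.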

Compound 3, half-maximal inhibitory concentration: > 30000 nM
Compound 3: only a limit was reported (the forecaster's own chance of this, stated with the estimate: 15%); at least 4.2-fold (0.63 log units) between middle value and limit.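

In this assay, the aromatic ring on the amine nitrogen responds not only to exchange of the whole group but also to a single added substituent: methoxy in place of hydrogen, ortho to a methoxy group, gives an at least 3.8-fold higher number from compound 2 to compound 3 (0.58 log units; beyond the scatter). Compound 3 gives only a limit, > 30000 nM. Of the groups on the amine nitrogen, only 4-methoxyphenyl has a number so far, and the step between compound 1 and compound 3 cannot be read, as both stand at one limit: the limit of > 30000 nM in this assay, at which 2 of the 3 values shown sit.

The compounds shown leave open whether this rise belongs to methoxy itself or would also follow from a fluorine, a methyl or a hydroxy group on the same carbon. They also leave open how an unsubstituted phenyl or a 4-ethoxyphenyl group on the amine nitrogen would compare with 4-methoxyphenyl.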